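A naphthalen-1-yl group on the carbonyl carbon

The source may hold more compounds than are shown below. What is called first, only, known or untested is meant among the compounds shown, and "the series" means these compounds.

Measured so far in a functional assay on C8166 cells (Homo sapiens) for cytotoxicity, read by MTT assay (a lower number here means that less compound is tolerated, a higher number that more compound is tolerated), two compounds:
- compound 1 `Cc1cc(S(N)(=O)=O)ccc1NC(=O)COc1ccc(Cl)cc1NC(=O)c1ccccc1` gives 207000 nM
- compound 2 `Cc1cc(S(N)(=O)=O)ccc1NC(=O)COc1ccc(Cl)cc1NC(=O)c1ccc(Cl)cc1Cl` gives 61100 nM

Of these two, compound 2 holds the lower number, so less of it is tolerated in this assay than of compound 1. The next compound to be tested is compound 3 `Cc1cc(S(N)(=O)=O)ccc1NC(=O)COc1ccc(Cl)cc1NC(=O)c1cccc2ccccc12`, which carries naphthalen-1-yl in place of 2,4-dichlorophenyl on a carbonyl carbon, and the rest of the core of compound 2 stays the same. The difference counts as follows: naphthalen-1-yl in place of 2,4-dichlorophenyl on a carbonyl carbon.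

Among the compounds with values here, only one measured step bears on this change: a 3.4-fold lower number from compound 1 to compound 2 (0.53 log units; beyond the scatter), where 2,4-dichlorophenyl replaced phenyl on that same carbonyl carbon. Within the data shown here, it shows that a change at this place can move the number modestly, but no measurement yet shows what naphthalen-1-yl does. A small move toward a higher number is therefore expected, smaller than that measured step. The expected change is a 1.5-fold higher number from compound 2 to compound 3 (0.17 log units; within the scatter), and this is only an estimate. For compound 3 the estimated value is 90000 nM, with an expected range of 35000 nM to 220000 nM.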

Compound 3, half-maximal cytotoxic concentration: > 381000 nM
Compound 3 ended at the assay's limit; the forecaster's own chance of this, stated with the estimate: 10%; middle value at least 4.2-fold (0.62 log units) away from the limit.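

In this assay compound 3 gives no exact number, only a limit of the assay: the limit of > 381000 nM in this assay, at which 1 of the 3 values shown sits. Within the data shown here, the only earlier step at this carbonyl carbon went toward a lower number, but this result shows that the group here can also move the number the other way, with an at least 6.2-fold higher number from compound 2 to compound 3 (0.79 log units; beyond the scatter) as naphthalen-1-yl replaces 2,4-dichlorophenyl. Set against the plain phenyl group, the change gives an at least 1.8-fold higher number from compound 1 to compound 3 (0.26 log units; that floor lies within the scatter), a floor that does not by itself set compound 3 apart from compound 1, so the clear separation so far lies between naphthalen-1-yl and 2,4-dichlorophenyl.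

On these data alone, compound 3 has no exact number, so the full size of both steps to it stays open, and the three compounds cannot separate the loss of the two chlorines from the arrival of the second aromatic ring. As far as these compounds go, it also remains open how a phenyl group carrying a single chlorine, or a pyridine ring, would behave on this carbonyl carbon, and either could help to tell those two parts of the change apart.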